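The source may hold more compounds than are shown below. What is called first, only, known or untested is meant among the compounds shown, and "the series" means these compounds.

In a functional assay on NCI-H1975 cells (Homo sapiens) for antiproliferative activity, read by sulforhodamine B assay, with a stated time of 72 h (a higher number here means a weaker inhibitor, a lower number a stronger inhibitor), compound 1 (`C/C=C/C(=O)Nc1cc(Nc2nccc(-c3cn(C)c4ccccc34)n2)c(OC)cc1N(C)CCN(C)C`) gives 496 nM and compound 2 (`C=C(C(=O)Nc1cc(Nc2nccc(-c3cn(C)c4ccccc34)n2)c(OC)cc1N(C)CCN(C)C)C(F)(F)F`) gives 546 nM, so the two stand level within the scatter. Compound 3 (`C=C(Cl)C(=O)Nc1cc(Nc2nccc(-c3cn(C)c4ccccc34)n2)c(OC)cc1N(C)CCN(C)C`) differs from compound 2 by chloro in place of trifluoromethyl on a double-bonded chain carbon bound to a carbonyl carbon, with chloro in place of trifluoromethyl on a double-bonded chain carbon bound to a carbonyl carbon. Going by the values given here, the one measured step, a 1.1-fold higher number from compound 1 to compound 2 (0.04 log units; within the scatter), stayed within the scatter, so no change beyond the scatter is expected in this assay. The expected change is a 1.4-fold lower number from compound 2 to compound 3 (0.14 log units; within the scatter). Compound 3 is estimated at 400 nM, with an expected range of 150 nM to 1000 nM.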

Compound 3, half-maximal inhibitory concentration: 241 nM
Compound 3: middle estimate off by 1.7-fold (0.22 log units), on the high side; measured number inside the range.
By their numbers in this assay, from the lowest: compound 3; then compounds 1 and 2 (each within the scatter of the next).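

In this assay the group on a double-bonded chain carbon bound to a carbonyl carbon now makes a difference: chloro in place of trifluoromethyl gives a 2.3-fold lower number from compound 2 to compound 3 (0.36 log units; beyond the scatter) and 1-chloroethenyl in place of prop-1-en-1-yl on a carbonyl carbon gives a 2.1-fold lower number from compound 1 to compound 3 (0.31 log units; beyond the scatter) with both steps modest. Going by these compounds alone, the earlier pair stood level, so the place is not indifferent to its group, and chloro is the one group of the three that separates from the others. No evidence at hand bears on this result. The compounds shown leave open whether bromo, fluoro or a nitrile at this place would match chloro. They also leave open how an unsubstituted ethenyl group would compare.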